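The source may report more compounds than this note shows. Statements on the series, on what has been measured and on what is new or still open speak of the compounds shown alone.

Two compounds of the series have been taken into a functional assay on Bel-7402 cells (Homo sapiens) for cytotoxicity, read by MTT assay, with a stated time of 48 h (on this read-out lower numbers stand for stronger inhibition and higher numbers for weaker inhibition), and neither yields a number. In this assay compound 1 `COc1ccc(-c2c[nH]c(=O)n2-c2cc(OC)c(OC)c(OC)c2)cc1[N+](=O)[O-]` gives "not determined" (no result reported), so it offers no reference point. In this assay compound 2 `COc1ccc(-c2cn(C(=O)Nc3cc(OC)c(OC)c(OC)c3)c(=O)n2-c2cc(OC)c(OC)c(OC)c2)cc1` reads > 50000 nM, which is a limit of the assay and not a number. Within the data shown here, no step between measured compounds is available to calibrate the series.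

Compound 3 `COc1ccc(-c2cn(C(=O)Nc3cc(OC)c(OC)c(OC)c3)c(=O)n2-c2cc(OC)c(OC)c(OC)c2)cc1N` differs from compound 2 in one place: amino in place of hydrogen on an aromatic carbon. This is amino in place of hydrogen on an aromatic carbon, taking 4-methoxyphenyl to 3-amino-4-methoxyphenyl. Among the measured compounds shown here, no measured pair shows what this change does, so its size remains uncertain.

With the limit of compound 2 at > 50000 nM, only a move toward stronger inhibition could register in this assay. A moderate gain is expected, and compound 3 may still end at a limit. The expected change is an at least 6.2-fold lower number from compound 2 to compound 3 (0.79 log units; beyond the scatter), an estimate that carries a wide margin. Compound 3 is estimated at 8000 nM, with an expected range of 300 nM to 50000 nM.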

Compound 3, half-maximal inhibitory concentration: 10100 nM
The estimate for compound 3 lay 1.3-fold (0.10 log units) below the measured number; measured number inside the range.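

In this assay, among these compounds, compound 3 reads 10100 nM, the first actual number, so this position on the 4-methoxyphenyl ring is the first place where a single change is seen to register in the assay. Going from 4-methoxyphenyl to 3-amino-4-methoxyphenyl, with amino in place of hydrogen ortho to the methoxy group, gives an at least 4.9-fold lower number from compound 2 to compound 3 (0.69 log units; beyond the scatter). That size is only a floor because the step starts from a limit and not from a number: the limit of > 50000 nM in this assay, at which 1 of the 3 values shown sits.

Still open, as far as these compounds go, is whether the gain is specific to amino, or whether hydroxyl, dimethylamino or acetamido on the same aromatic carbon would read the same in this assay. Also open, from the compounds shown here alone, are the true size of the step, which stays unknown while compound 2 has only a limit, and whether amino at another place on this ring would give a similar shift.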